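Trimethoxyphenyl pyrazole chalcones: removing one methoxy group

A few compounds are considered here, and "the series" means these few. Any claim that something is new, unique, unknown or untested is made for them only; others in the source may bear on it.

Compound 1 `COc1cc(-c2cc(/C=C/C(=O)c3ccc(N)cc3)[nH]n2)cc(OC)c1OC` is the reference for this step. In a functional assay on UACC-257 cells (Homo sapiens) for cytotoxicity, read by sulforhodamine B assay, with a stated time of 48 h, tested at 1 uM (a higher number here means a weaker effect of the compound at the concentration tested, a lower number a stronger effect), compound 1 gives 91%. Going by the values given here, compound 3 `COc1cc(-c2cc(/C=C/C(=O)c3ccc(Cl)c(Cl)c3)[nH]n2)cc(OC)c1OC` gives 90% in this assay, and the only single-place step among the measured compounds, a number 1 percentage points lower from compound 1 to compound 3 (within the scatter), is within the scatter. Among the compounds with values here, compound 2 `COc1ccc(-c2cc(/C=C/C(=O)c3ccc(OC)c(OC)c3)[nH]n2)cc1` gives 87%, also within the scatter of compound 1; it carries a single methoxy group on the ring attached to the core and two on the other ring, so it differs from compound 1 in more than one place and gives no step on its own.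

Compound 4 `COc1ccc(-c2cc(/C=C/C(=O)c3ccc(N)cc3)[nH]n2)cc1OC` is to be measured. Relative to compound 1 the change is hydrogen in place of methoxy on an aromatic carbon. Within the data shown here, no measured step touches this position; the one step available, from compound 1 to compound 3, concerned the other ring and stayed within the scatter, and compound 2, with fewer methoxy groups on the same ring, also sits within the scatter of compound 1. The expectation is therefore no step beyond the scatter in this assay. For compound 4 the estimate is 89%, between 78% and 98%, an expected step of a number 2 percentage points lower from compound 1 to compound 4 (within the scatter).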

Compound 4, a percentage reported as activity, at one concentration (the size of the read-out at that concentration, not a potency): 96%
The estimate for compound 4 lay 7 percentage points below the measured number; measured number inside the range.
By their numbers in this assay, from the lowest: compounds 2, 3, 1 and 4 (each within the scatter of the next).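

In this assay, going by these compounds alone, hydrogen in place of methoxy gives a number 5 percentage points higher from compound 1 to compound 4 (within the scatter) and is the first measured step on this ring, the one carrying the methoxy groups in compound 1. Removing this methoxy group, on a carbon ortho to a methoxy group, therefore gives no change that can be read at the single concentration tested, so the group is not shown to matter for this read-out. No measurement available here bears on why this step stays so small.

As far as these compounds go, whether another group on this aromatic carbon, such as an amine, a carboxylic acid or a longer alkoxy chain, would give a step beyond the scatter remains open. Also open, from the compounds shown here alone, is whether the same removal would read differently with the 3,4-dichlorophenyl group of compound 3 on the carbonyl carbon.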